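Replacing carbamoyl with 4-nitrophenyl on a shared core

The source may hold more compounds than are shown below. What is called first, only, known or untested is meant among the compounds shown, and "the series" means these compounds.

Measured so far in a functional assay with Mus musculus as the target; a lower number here means that less compound is needed, a higher number that more compound is needed for the effect:
compound 1 `C=CCn1c(=O)n(CCCCO)c2nc(N)nc(O)c21` gives 52 uM
compound 2 `C=CCn1c(=O)n(C2C=CC(CO)O2)c2nc(N)nc(O)c21` gives 30 uM
compound 3 `NC(=O)Cn1c(=O)n(C2OC(CO)[C@@H](O)[C@H]2O)c2nc(N)nc(O)c21` gives 117 uM

Compound 3 stands highest of the three numbers; compound 1 lies nearest to it and compound 2 furthest, both with a gap beyond the scatter. Compound 4 `Nc1nc(O)c2c(n1)n(C1OC(CO)[C@@H](O)[C@H]1O)c(=O)n2Cc1ccc([N+](=O)[O-])cc1` is not yet measured in this assay. It differs from compound 3 in one place: 4-nitrophenyl in place of carbamoyl on a saturated chain carbon bound to an aromatic nitrogen.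

For the measured compounds named here, only one step between measured compounds exists, a 1.7-fold lower number from compound 1 to compound 2 (0.24 log units; within the scatter), and it changes the group on the other aromatic nitrogen, not the group on the saturated chain carbon. Going by the values given here, no measured pair alters the carbamoylmethyl group on its own, so nothing bears directly on this change. Compounds 1 and 2 carry a hydrocarbon group on that nitrogen and give the lower numbers, but they also differ from compound 3 elsewhere, so they cannot be read as a clean precedent. The step of a 1.7-fold lower number from compound 3 to compound 4 (0.22 log units; within the scatter) is therefore expected to be small, with a wide range in both directions. For compound 4 the estimate in this assay is 70 uM, between 25 uM and 200 uM.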

Compound 4, concentration for half-maximal effect: 50 uM
Compound 4: middle estimate off by 1.4-fold (0.15 log units), on the high side; measured number inside the range.
By their numbers in this assay, from the lowest: compounds 2, 4 and 1 (each within the scatter of the next); then compound 3.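

In this assay, for the compounds shown here, 4-nitrophenyl in place of carbamoyl on a saturated chain carbon bound to an aromatic nitrogen gives a 2.3-fold lower number from compound 3 to compound 4 (0.37 log units; beyond the scatter), the first clean reading at this position, and it shows that the number responds, modestly, to the group placed there. Going by these compounds alone, the only earlier step, a 1.7-fold lower number from compound 1 to compound 2 (0.24 log units; within the scatter), lay within the scatter and concerned a different group on an aromatic nitrogen, so it gave no such information. Nothing measured accounts for the size or direction of the new step.

The compounds shown leave open whether the step belongs to the aromatic ring or to its nitro group, a question that plain phenyl or 4-aminophenyl on the same chain carbon would address. They also leave open how a carboxylic acid in place of carbamoyl would read.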